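A few compounds are considered here, and "the series" means these few. Any claim that something is new, unique, unknown or untested is made for them only; others in the source may bear on it.

Compound 1 `O=C(CCSc1nnc(-c2ccncc2)s1)Nc1c(Cl)cccc1Cl` gives 12600 nM in an ADME assay on HepG2 cells (Homo sapiens) for cytotoxicity, with a stated time of 3 days; on this read-out higher numbers stand for lower toxicity in this test and lower numbers for higher toxicity in this test. Compound 2 `CC(CSc1nnc(-c2ccncc2)s1)C(=O)NCc1ccccc1Cl` gives only a limit, > 50000 nM, in this assay. Compound 3 `CC(CSc1nnc(-c2ccncc2)s1)C(=O)Nc1ccc(Cl)cc1` likewise gives only a limit, > 50000 nM, in this assay.

Compound 3 therefore sits at the limit of > 50000 nM in this assay, at which 2 of the 3 values shown sit, and it cannot be placed more closely than that. Within the data shown here, the single measured step, a step that the two limits leave unreadable from compound 2 to compound 3, is unreadable for the same reason. Compound 4 `CC(CSc1nnc(-c2ccncc2)s1)C(=O)Nc1c(Cl)cccc1Cl` arises from compound 3 by the change (2,6-dichlorophenyl in place of 4-chlorophenyl on an amide-type nitrogen). Among the measured compounds shown here, no measured step shows this exact change. Compound 1, which carries the same 2,6-dichlorophenyl, gives a number rather than a limit in this assay. A step toward higher toxicity, an at least 2.0-fold lower number from compound 3 to compound 4 (0.30 log units; that floor lies within the scatter), is therefore expected, though its size is uncertain. Compound 4 is estimated at 25000 nM in this assay, within 8000 nM to 80000 nM.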

Compound 4, half-maximal cytotoxic concentration: > 50000 nM
Compound 4: only a limit was reported; the forecaster's own chance of this, stated with the estimate: 40%; middle value at least 2.0-fold (0.30 log units) away from the limit.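

Compound 4 also gives only a limit in this assay, so its steps to compound 2 and compound 3 cannot be read, and it joins them: the limit of > 50000 nM in this assay, at which 3 of the 4 values shown sit. With the 2,6-dichlorophenyl kept, methyl in place of hydrogen on the saturated chain carbon bound to the carbonyl carbon is an at least 3.9-fold higher number from compound 1 to compound 4 (0.59 log units; beyond the scatter). The 2,6-dichlorophenyl alone therefore does not bring a number under the limit; among the compounds shown, only compound 1, without the methyl, has one.

As far as these compounds go, how far compounds 2, 3 and 4 lie past the limit stays open, so their groups on the nitrogen cannot be ranked. From the compounds shown here alone, whether a longer chain in place of that methyl would give a measurable number is also open.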